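Compound 1 to Compound 4: One Ring Exchanged

This account rests on a few compounds, and the source may have more. Where it says the series, first, only, none or still open, it means among the compounds named here.

Measured in an assay for inhibition of kynurenine 3-monooxygenase (Homo sapiens), read by mass spectrometry, with a stated time of 1 h; on this read-out lower numbers stand for stronger inhibition and higher numbers for weaker inhibition:
- compound 1 `C[C@@H](Oc1cc2oc(=O)n(CCC(=O)O)c2cc1Cl)c1ccc(F)cn1`: 2.51 nM
- compound 2 `COc1cc2oc(=O)n(CCC(=O)O)c2cc1Cl`: 12.6 nM
- compound 3 `C[C@@H](Oc1cc2onc(CCC(=O)O)c2cc1Cl)c1ccc(F)cn1`: 3.16 nM

Compound 1 has the lowest number of the three. Compound 3 sits within the scatter of it, so the two cannot be ordered; compound 2 lies beyond the scatter, with the higher number. Compound 4 `Cc1cccc([C@@H](C)Oc2cc3oc(=O)n(CCC(=O)O)c3cc2Cl)n1` differs from compound 1 in one place: 6-methylpyridin-2-yl in place of 5-fluoropyridin-2-yl on a saturated chain carbon bound to an oxygen on an aromatic ring and a saturated chain carbon. Among the compounds with values here, no pair of measured compounds isolates this exchange, so the expectation rests on the closeness of compound 1 and compound 3 alone. The step of a 1.4-fold higher number from compound 1 to compound 4 (0.14 log units; within the scatter) is expected to be small, likely none beyond the scatter, with a slight lean toward a higher number. Compound 4 is therefore estimated at 3.5 nM, in a range from 1.2 nM to 10 nM.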

Compound 4, half-maximal inhibitory concentration: 5.01 nM
Compound 4: the middle estimate sits 1.4-fold (0.16 log units) below what was measured; measured number inside the range.
By their numbers in this assay, from the lowest: compounds 1, 3 and 4 (each within the scatter of the next); then compound 2.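

The step reads a 2.0-fold higher number from compound 1 to compound 4 (0.30 log units; within the scatter) in this assay, so 5-fluoropyridin-2-yl and 6-methylpyridin-2-yl cannot be told apart at this place. Within the data shown here, this is the first single exchange seen on this saturated chain carbon, and it shows that a fluorine-bearing pyridine and a methyl-bearing pyridine, each of 7 heavy atoms, are not separated beyond the scatter. No measurement available here accounts for this result. Still open, going by these compounds, is how a phenyl, a morpholine or a longer chain on this carbon would compare with compound 1. Also open, on these data alone, is whether 6-methylpyridin-2-yl would read alike on the core of compound 3.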